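This account rests on a few compounds, and the source may have more. Where it says the series, first, only, none or still open, it means among the compounds named here.

Measured so far:
compound 1, `Cc1cccc2c(=O)c(-c3nn[nH]n3)c[nH]c12`: in a functional assay on the whole organism (strain Sprague-Dawley) for inhibition, with Rattus norvegicus as the target (on this read-out lower numbers stand for an effect already at smaller amounts and higher numbers for an effect only at larger amounts of compound), compound 1 gives > 10 mg/kg
compound 2, `COc1ccc(OC)c2ncc(-c3nn[nH]n3)cc12`: in this assay compound 2 gives > 50 mg/kg

Both of these numbers are limits of this assay, not measured values. Compound 1 stands at the limit of > 10 mg/kg in this assay, at which 1 of the 2 values shown sits. Compound 2 stands at the limit of > 50 mg/kg in this assay, at which 1 of the 2 values shown sits. Within the data shown here, no step between measured compounds exists, so there is nothing to lean on. Compound 3, `CC(C)Oc1cccc2c(=O)c(-c3nn[nH]n3)c[nH]c12`, differs from compound 1 by isopropoxy in place of methyl on an aromatic carbon. The step from compound 1 to compound 3 is expected to be no change beyond the scatter, a step that the limit leaves unreadable from compound 1 to compound 3. Compound 3 is therefore estimated to give about 20 mg/kg in this assay, within 5 mg/kg to 100 mg/kg.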

Compound 3, minimum effective dose: 1.25 mg/kg
The estimate for compound 3 lay 16-fold (1.20 log units) above the measured number; measured number outside the range, below it.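

Isopropoxy in place of methyl on this aromatic carbon brings an at least 8.0-fold lower number from compound 1 to compound 3 (0.90 log units; beyond the scatter) in this assay. This position can therefore carry a change that moves the result, which the two limits alone could not show. The true size of the step stays unknown, because the number for compound 1 is a limit and not a measured value: the limit of > 10 mg/kg in this assay, at which 1 of the 3 values shown sits.

Still open, going by these compounds, is whether the oxygen or the branched chain matters, which a methoxy group or a propyl chain on the same carbon could separate. On these data alone, how an amine there would behave also stays open.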